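Ethyl to methyl on the sulfanyl aryl group

The source may hold more compounds than are shown below. What is called first, only, known or untested is meant among the compounds shown, and "the series" means these compounds.

In a functional assay on A-375 cells (Homo sapiens) for inhibition, read by CCK-8 assay, with a stated time of 72 h, tested at 8 uM (a higher number here means more inhibition of growth at the concentration tested, a lower number less inhibition of growth), compound 1 `Nc1ccccc1NC(=O)/C=C/c1ccc(CSc2ccc(Cl)cc2)cc1` gives 48.2%, and compound 2 `CCc1ccc(SCc2ccc(/C=C/C(=O)Nc3ccccc3N)cc2)cc1` gives 58.4%. Within the data shown here, compound 2 therefore holds the higher of the two numbers so far. Among the measured compounds shown here, only one measured step is available: ethyl in place of chloro on an aromatic carbon gives a number 10.2 percentage points higher from compound 1 to compound 2 (beyond the scatter).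

Compound 3 `Cc1ccc(SCc2ccc(/C=C/C(=O)Nc3ccccc3N)cc2)cc1` follows from compound 2 by hydrogen in place of methyl on a saturated chain carbon bound to an aromatic carbon. This is hydrogen in place of methyl on a saturated chain carbon bound to an aromatic carbon, so that (4-ethylphenyl)sulfanyl becomes (4-methylphenyl)sulfanyl. For the measured compounds named here, no measured pair shows this exact change. Going by the values given here, the chloro-to-ethyl step, a number 10.2 percentage points higher from compound 1 to compound 2 (beyond the scatter), concerns the same group and is the only guide, though an indirect one. Shortening ethyl to methyl is a smaller edit than that exchange, so only part of that step is expected to be given back. The expected step is a number 5.4 percentage points lower from compound 2 to compound 3 (within the scatter), a small drop that is not expected to stand clearly beyond the scatter. The estimate for compound 3 is 53%, with an expected range of 41% to 65%.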

Compound 3, percent growth inhibition at one concentration: 31.2%
For compound 3 the middle estimate is 21.8 percentage points above the measured one; the measured number lies below the stated range.
By their numbers in this assay, from the lowest: compound 3; then compound 1; then compound 2.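

In this assay, shortening ethyl to methyl on the sulfanyl aryl group has a clear effect, with a number 27.2 percentage points lower from compound 2 to compound 3 (beyond the scatter). Methyl also does not take an intermediate place between chloro and ethyl, as shown by a number 17 percentage points lower from compound 1 to compound 3 (beyond the scatter); the order of the three compounds at this position is therefore methyl in compound 3, chloro in compound 1 and ethyl in compound 2, with each listed step beyond the scatter. The earlier chloro-to-ethyl comparison could not show that the two alkyl groups fall on opposite sides of chloro, or that a change of 1 carbon at this position can alter the read-out this much.

Nothing available accounts for the drop from ethyl to methyl. From the compounds shown here alone, it remains open whether a longer chain such as propyl or butyl, or a different group such as methoxy or an amine on the same aryl group, would exceed the number for compound 2 at 58.4% or would instead fall back towards the number for compound 3 at 31.2%.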